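From cyclohexyloxy to (quinolin-8-yl)amino on a shared core

The source may hold more compounds than are shown below. What is called first, only, known or untested is meant among the compounds shown, and "the series" means these compounds.

In a functional assay on Shh Light II cells (Mus musculus) for inhibition, read by a luciferase reporter (a higher number here means a weaker inhibitor, a lower number a stronger inhibitor), compound 3 `O=C(OC1CCCCC1)N1CCC(c2nc(-c3ccc4ccccc4n3)no2)CC1` gives 580 nM, compound 1 `O=C(Nc1ccccc1Cl)N1CCC(c2nc(-c3ccc4ccccc4n3)no2)CC1` gives 510 nM, and compound 2 `O=C(CC1CCCCCC1)N1CCC(c2nc(-c3ccc4ccccc4n3)no2)CC1` gives 840 nM. All three lie within the scatter of one another, so compound 3 holds no distinct place among them. Compound 4 `O=C(Nc1cccc2cccnc12)N1CCC(c2nc(-c3ccc4ccccc4n3)no2)CC1` differs from compound 3 as follows: (quinolin-8-yl)amino in place of cyclohexyloxy on a carbonyl carbon. In words, it has (quinolin-8-yl)amino in place of cyclohexyloxy on a carbonyl carbon. Going by the values given here, two measured steps bear on this change: a 1.1-fold higher number from compound 1 to compound 3 (0.06 log units; within the scatter), with cyclohexyloxy in place of (2-chlorophenyl)amino, and a 1.4-fold lower number from compound 2 to compound 3 (0.16 log units; within the scatter), with cyclohexyloxy in place of cycloheptylmethyl. Neither leaves the scatter, so no step beyond it is expected in this assay. The estimated change is a 1.1-fold lower number from compound 3 to compound 4 (0.02 log units; within the scatter). For compound 4 the estimated value is 550 nM, with an expected range of 220 nM to 1400 nM.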

Compound 4, half-maximal inhibitory concentration: 1400 nM
Compound 4: the middle estimate sits 2.5-fold (0.41 log units) below what was measured, within the range that was stated.
By their numbers in this assay, from the lowest: compounds 1, 3, 2 and 4 (each within the scatter of the next, the first and the last beyond it).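

Going by these compounds alone, at this carbonyl carbon, no change among the earlier compounds had left the scatter in this assay, but (quinolin-8-yl)amino does so with a 2.4-fold higher number from compound 3 to compound 4 (0.38 log units; beyond the scatter) and with a 2.7-fold higher number from compound 1 to compound 4 (0.44 log units; beyond the scatter), both modest steps, while a 1.7-fold higher number from compound 2 to compound 4 (0.22 log units; within the scatter) stays within it. The step from compound 1 keeps the amide-type nitrogen, so exchanging 2-chlorophenyl for quinolin-8-yl on that nitrogen is enough to produce a modest step. Nothing available explains this result. The compounds shown leave open whether a plain phenyl or a pyridinyl on that nitrogen would read like compound 1 or like compound 4.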